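A few compounds are considered here, and "the series" means these few. Any claim that something is new, unique, unknown or untested is made for them only; others in the source may bear on it.

Within the data shown here, compound 1 `Cc1cn([C@@H]2O[C@H](CO[Si](C)(C)C(C)(C)C)[C@@]3(OS(=O)(=O)C=C3NC(N)=O)[C@H]2O[Si](C)(C)C(C)(C)C)c(=O)n(C)c1=O` is the only member of this small set to give a plain number in a functional assay on HEL cells (Homo sapiens) for cytotoxicity, read by microscopy; a higher number here means that more compound is tolerated, a lower number that less compound is tolerated: compound 1 gives 16000 nM. Compound 2 `Cc1cn([C@@H]2O[C@H](CO[Si](C)(C)C(C)(C)C)[C@@]3(OS(=O)(=O)C=C3NCC(=O)OCc3ccccc3)[C@H]2O[Si](C)(C)C(C)(C)C)c(=O)n(C)c1=O` reaches only a limit of the assay, >= 400000 nM. Compound 3 `Cc1cn([C@@H]2O[C@H](CO[Si](C)(C)C(C)(C)C)[C@@]3(OS(=O)(=O)C=C3NC(=O)NC(=O)c3ccccc3)[C@H]2O[Si](C)(C)C(C)(C)C)c(=O)n(C)c1=O` likewise stops at a limit, >= 80000 nM. The two exchanges at the amine nitrogen of the shared core thus both move the read-out upward: an at least 25-fold higher number from compound 1 to compound 2 (1.39 log units; beyond the scatter), and an at least 5.0-fold higher number from compound 1 to compound 3 (0.69 log units; beyond the scatter). Between the two limits the remaining comparison cannot be read: a step that the two limits leave unreadable from compound 2 to compound 3. Compound 1 therefore stands at the low end of the numbers shown, with both neighbours at a limit, the limit of >= 400000 nM in this assay, at which 1 of the 3 values shown sits, and (the limit of >= 80000 nM in this assay, at which 1 of the 3 values shown sits).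

Compound 4 `Cc1cn([C@@H]2O[C@H](CO[Si](C)(C)C(C)(C)C)[C@@]3(OS(=O)(=O)C=C3NCC(=O)O)[C@H]2O[Si](C)(C)C(C)(C)C)c(=O)n(C)c1=O` differs from compound 1 in one place: carboxymethyl in place of carbamoyl on an amine nitrogen. Among the measured compounds shown here, the step that bears most directly on it is the one from compound 1 to compound 2, where a (benzyloxycarbonyl)methyl also replaced the carbamoyl and the number rose by a large amount. For the measured compounds named here, since the same kind of exchange at the same nitrogen is made here, a rise in this assay is expected, though the only comparable step ended at a limit, so its full size is unknown. The expected step is a 6.3-fold higher number from compound 1 to compound 4 (0.80 log units; beyond the scatter). Compound 4 is accordingly estimated at 100000 nM, within a range from 20000 nM to 400000 nM.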

Compound 4, minimum cytotoxic concentration: 300000 nM
The estimate for compound 4 lay 3.0-fold (0.48 log units) below the measured number; measured number inside the range.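

Among these compounds, compound 4 gives the first plain number for an exchange at this amine nitrogen, so the rise that earlier appeared only as a floor now has a size in this assay: carboxymethyl in place of carbamoyl gives a 19-fold higher number from compound 1 to compound 4 (1.27 log units; beyond the scatter). With hydrogen in place of benzyl, the comparison with the benzyl ester gives an at least 1.3-fold lower number from compound 2 to compound 4 (0.12 log units; that floor lies within the scatter), and since compound 4 carries no benzyl group, the large rise from compound 1 does not require that group. The step involving the benzoylcarbamoyl compound cannot be read, because compound 3 stands at a limit: the limit of >= 80000 nM in this assay, at which 1 of the 4 values shown sits.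

The compounds shown leave open whether the rise depends on the free carboxylic acid, since a primary amide or a methyl ester on the same methylene, or a longer chain such as carboxyethyl, would be needed to separate the end group from the chain. They also leave open how a simple amine at this nitrogen, with neither carbamoyl nor carboxymethyl, would compare with compound 1 and compound 4 in this assay.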